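From (3-chlorophenyl)amino to 3-chlorophenoxy

The compounds below may be only part of what the source reports. "The series", "measured", "known", "first", "only" and "open" are said of these compounds alone.

Of the compounds shown here, three have been measured in an ADME assay on microsomes from liver (Rattus norvegicus) for metabolic stability, read by LC-MS, tested at 1 uM; a higher number here means that the compound lasts longer, a lower number that the compound disappears faster. Compound 1 `Cc1cccc(Oc2nn(C(C)(C)C)c3ncnc(N)c23)c1` gives 0.07 h, compound 2 `CC(C)(C)n1nc(Oc2cc(F)cc(F)c2)c2c(N)ncnc21` gives 0.55 h, and compound 3 `Nc1ncnc2c1c(Nc1cccc(Cl)c1)nn2CC1CCNCC1` gives 0.333 h. Compound 3 thus stands second of the three numbers, within the scatter of compound 2 and beyond the scatter above compound 1.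

Compound 4 `Nc1ncnc2c1c(Oc1cccc(Cl)c1)nn2CC1CCNCC1` carries 3-chlorophenoxy in place of (3-chlorophenyl)amino on an aromatic carbon. Among the compounds with values here, no measured pair isolates this exchange, so no shift beyond the scatter is assumed in this assay. The estimated step of a 1.0-fold lower number from compound 3 to compound 4 (0.00 log units; within the scatter) is expected to stay within the scatter. For compound 4 the expected half-life is 0.33 h, with an estimated range of 0.14 h to 0.8 h.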

Compound 4, half-life: > 1 h
Compound 4 gave a limit, no number; the forecaster's own chance of this, stated with the estimate: 3%; middle value at least 3.0-fold (0.48 log units) away from the limit.
By their numbers in this assay, from the lowest: compound 1; then compounds 3 and 2 (each within the scatter of the next). At a limit, above all of these: compound 4.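

Within the data shown here, replacing (3-chlorophenyl)amino with 3-chlorophenoxy on this aromatic carbon gives the first comparison that differs in one place, with a rise of an at least 3.0-fold higher number from compound 3 to compound 4 (0.47 log units; beyond the scatter). Among these compounds, the atom linking the chlorophenyl ring to the shared core therefore matters here, which the earlier compounds could not show. As far as these compounds go, compound 4 gives > 1 h as a limit of the assay and not a number, so the full size of the step stays unknown: the limit of > 1 h in this assay, at which 1 of the 4 values shown sits.

From the compounds shown here alone, how a sulfur or methylene link would compare at this place remains open. Also open, going by these compounds, is whether the exchange carries over when a group other than (piperidin-4-yl)methyl sits on the ring nitrogen.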